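The source may report more compounds than this note shows. Statements on the series, on what has been measured and on what is new or still open speak of the compounds shown alone.

Two compounds of the series carry numbers in an ADME assay on microsomes from liver (Homo sapiens) for metabolic stability, read by HPLC, using NADPH, with a stated time of 60 min, tested at 1 uM, in the presence of a further agent that is not named here; a higher number here means faster removal of the compound, a lower number slower removal. Compound 1 `O=C(NNS(=O)(=O)c1ccccc1F)c1cc(F)cc(-n2cccn2)c1` gives 18 uL/min in this assay. Compound 2 `Cc1cc(-c2ncccn2)cc(C(=O)NNS(=O)(=O)c2ccccc2)c1F` gives 11 uL/min in this assay, the lowest of the two numbers shown, with compound 1 as its nearest neighbour at a gap that lies within the scatter, so the two are read as indistinguishable. Among the compounds with values here, no step between measured compounds that differ in one place is available. Compound 3 `Cc1cc(-n2nccn2)cc(C(=O)NNS(=O)(=O)c2ccccc2)c1F` has not yet been measured. It differs from compound 2 as follows: 2H-1,2,3-triazol-2-yl in place of pyrimidin-2-yl on an aromatic carbon. The rest of the shared core is unchanged. Within the data shown here, with only two numbers at hand, and those within the scatter of each other, no step beyond the scatter is expected in this assay in either direction. The value expected for compound 3 is 12 uL/min, with a range of 6 uL/min to 24 uL/min. This corresponds to an expected step of a 1.1-fold higher number from compound 2 to compound 3 (0.04 log units; within the scatter) that stays within the scatter.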

Compound 3, intrinsic clearance in a liver preparation (reported as CLH), per the amount of preparation that the assay uses: 28 uL/min
For compound 3 the middle estimate is 2.3-fold (0.37 log units) below the measured one, outside the stated range (above it).
By their numbers in this assay, from the lowest: compounds 2, 1 and 3 (each within the scatter of the next, the first and the last beyond it).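

On the aromatic carbon meta to a methyl group and para to a fluoro group, 2H-1,2,3-triazol-2-yl in place of pyrimidin-2-yl gives a 2.5-fold higher number from compound 2 to compound 3 (0.41 log units; beyond the scatter) in this assay. Within the data shown here, this is the first change at a single place that can be read, and it shows that the number in this assay responds to the ring on this carbon, with the pyrimidin-2-yl of compound 2 giving the slower removal of the pair. Nothing at hand accounts for the step.

The exchange alters ring size and hetero atom count together, and this one step does not separate the two. From the compounds shown here alone, whether a phenyl ring or a morpholine on the same carbon would fall nearer to compound 2 or to compound 3 remains open.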